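Methyl in Place of 4-Fluorophenyl on a Ring Amine

The source may report more compounds than this note shows. Statements on the series, on what has been measured and on what is new or still open speak of the compounds shown alone.

Measured compounds:
compound 1 `Nc1ccccc1NC(=O)c1ccc(CSC(=S)N2CCN(Cc3ccccn3)CC2)cc1`: 61.4%
compound 2 `Nc1ccccc1NC(=O)c1ccc(CSC(=S)N2CCN(c3ccc(F)cc3)CC2)cc1`: 64.5%

In a functional assay on HeLa cells (Homo sapiens) for antiproliferative activity, read by CCK-8 assay, with a stated time of 72 h, tested at 8 uM (a higher number here means a stronger effect of the compound at the concentration tested, a lower number a weaker effect), compound 1 gives 61.4% while compound 2 gives 64.5%. Compound 2 stands highest of the two numbers, but the gap to compound 1 is small: a number 3.1 percentage points higher from compound 1 to compound 2 (within the scatter). Compound 3 `CN1CCN(C(=S)SCc2ccc(C(=O)Nc3ccccc3N)cc2)CC1` carries a change at the same ring nitrogen: methyl in place of 4-fluorophenyl on an amine nitrogen in a ring. Among the compounds with values here, the one measured step at that position, a number 3.1 percentage points higher from compound 1 to compound 2 (within the scatter), stayed within the scatter, so a change here of little consequence is expected, and the expected step is a number 6.5 percentage points lower from compound 2 to compound 3 (within the scatter). Compound 3 is therefore estimated at 58%, with a range from 40% to 72%.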

Compound 3, a percentage reported as inhibition, at one concentration (the size of the read-out at that concentration, not a potency): 75.7%
Compound 3: middle estimate off by 17.7 percentage points, on the low side, and the stated range ends below it.
By their numbers in this assay, from the lowest: compounds 1 and 2 (each within the scatter of the next); then compound 3.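

In this assay, the ring nitrogen proves more sensitive than the earlier pair suggested: methyl in place of 4-fluorophenyl gives a step beyond the scatter (a number 11.2 percentage points higher from compound 2 to compound 3 (beyond the scatter)). Removing pyridin-2-yl from the saturated chain carbon, which leaves methyl on the ring nitrogen, gives a similar result (a number 14.3 percentage points higher from compound 1 to compound 3 (beyond the scatter)). The two ring-bearing groups therefore did not reveal what a single carbon here could do.

Nothing shown explains this gain. On these data alone, whether ethyl, a longer chain or a plain hydrogen on that nitrogen would keep it remains open.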